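A few compounds are considered here, and "the series" means these few. Any claim that something is new, unique, unknown or untested is made for them only; others in the source may bear on it.

Within the data shown here, compound 1 `CC1CCN(C2CCN(S(=O)(=O)c3cccc(-c4ccccc4F)c3)CC2)CC1` is the only compound in this set that gives a number rather than a limit in a functional assay on DLD-1 cells (Homo sapiens) for antiproliferative activity, read by CellTiter-Glo, with a stated time of 72 h (on this read-out lower numbers stand for stronger inhibition and higher numbers for weaker inhibition), and compound 1 gives 10 nM. Compound 2 `CC1CCN(C2CCN(S(=O)(=O)c3cccnc3Cl)CC2)CC1` reaches only the limit of > 5000 nM in this assay. Compound 3 `CC1CCN(C2CCN(S(=O)(=O)c3sc(Cl)nc3C3CC3)CC2)CC1` likewise stops at the limit of > 5000 nM. Among the measured compounds shown here, two of the three values sit at the limit of > 5000 nM in this assay, at which 2 of the 3 values shown sit, so compound 1 stands alone with a measured number, and no measured step between two compounds differing in one place is available. Compound 4 `Cc1cc(C)cc(-c2cccc(S(=O)(=O)N3CCC(N4CCC(C)CC4)CC3)c2)c1` has not yet been measured. It differs from compound 1 in one place: 3,5-dimethylphenyl in place of 2-fluorophenyl on an aromatic carbon. Compound 1 and compound 4 both keep a six-membered aromatic ring of carbon only joined to the shared core, which compound 2 and compound 3 do not have. The step expected is a 2.5-fold higher number from compound 1 to compound 4 (0.40 log units; beyond the scatter), most likely a small change within or only just beyond the usual scatter. Compound 4 is therefore estimated at 25 nM, with a range from 5 nM to 200 nM.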

Compound 4, half-maximal inhibitory concentration: 41 nM
Estimate against measurement, compound 4: 1.6-fold (0.21 log units) below; low and high end bracket the measured number.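

Among these compounds, replacing 2-fluorophenyl with 3,5-dimethylphenyl gives a 4.1-fold higher number from compound 1 to compound 4 (0.61 log units; beyond the scatter), the first measured step in this set, and it shows that this assay responds to a change at this place. The change is modest: the six-membered aromatic ring of carbon only stays, the fluorine leaves, the methyl groups enter, and compound 4 still gives a number, 41 nM, rather than a limit. Compound 2 and compound 3 remain limits of the assay, not numbers, and each differs from compound 1 in more than one place, so neither can be set against this step: the limit of > 5000 nM in this assay, at which 2 of the 4 values shown sit.

This single step does not separate the loss of the fluorine from the gain of the methyl groups. Going by these compounds, it also remains open how an unsubstituted phenyl, or a phenyl carrying an amine or a carboxylic acid, would behave at this place.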